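A few compounds are considered here, and "the series" means these few. Any claim that something is new, unique, unknown or untested is made for them only; others in the source may bear on it.

In a functional assay on HOS cells (Homo sapiens) for antiproliferative activity, read by sulforhodamine B assay (a higher number here means a weaker inhibitor of growth, a lower number a stronger inhibitor of growth), compound 1 (`c1ccc(COC[C@H]2OCC[C@@H](OCc3ccccc3)[C@@H]2OCc2ccccc2)cc1`) gives 22200 nM, compound 2 (`O[C@H]1CO[C@H](COCc2ccccc2)[C@@H](OCc2ccccc2)[C@@H]1OCc1ccccc1`) gives 37900 nM, and compound 3 (`CC(C)C[C@H]1O[C@H](COCc2ccccc2)[C@@H](OCc2ccccc2)[C@H](OCc2ccccc2)[C@H]1O`) gives 44500 nM. Compound 2 holds the middle place of these three numbers, but that place carries little weight, since both of its measured steps stay within the scatter: a 1.7-fold higher number from compound 1 to compound 2 (0.23 log units; within the scatter), and a 1.2-fold higher number from compound 2 to compound 3 (0.07 log units; within the scatter). The next compound, compound 4 (`OCC[C@@H]1O[C@H](COCc2ccccc2)[C@@H](OCc2ccccc2)[C@H](OCc2ccccc2)[C@H]1O`), has 2-hydroxyethyl in place of hydrogen on a saturated ring carbon of compound 2: 2-hydroxyethyl in place of hydrogen on a saturated ring carbon. Within the data shown here, the closest precedent is compound 3, which also replaces hydrogen on a saturated ring carbon, with isobutyl, and that change gave only a 1.2-fold higher number from compound 2 to compound 3 (0.07 log units; within the scatter). The step to compound 2 from compound 1, a 1.7-fold higher number from compound 1 to compound 2 (0.23 log units; within the scatter), is a hydroxy change and bears on this one less directly. Among the measured compounds shown here, no measured compound carries the 2-hydroxyethyl group, so the expectation rests on a single close step. No shift beyond the scatter is expected, and the estimated step is a 1.1-fold higher number from compound 2 to compound 4 (0.04 log units; within the scatter). The estimated value for compound 4 is 42000 nM, within a range of 20000 nM to 85000 nM.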

Compound 4, concentration for 50% growth inhibition: 39700 nM
Compound 4: the middle estimate sits 1.1-fold (0.02 log units) above what was measured, within the range that was stated.
By their numbers in this assay, from the lowest: compounds 1, 2, 4 and 3 (each within the scatter of the next).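

In this assay, the saturated ring carbon next to the ring oxygen of compound 2 now bears 2-hydroxyethyl, giving a 1.0-fold higher number from compound 2 to compound 4 (0.02 log units; within the scatter). Set beside a 1.2-fold higher number from compound 2 to compound 3 (0.07 log units; within the scatter), this means that two different chains on a saturated ring carbon, one of them with a hydrogen-bond donor and a hydrogen-bond acceptor, both stay within the scatter of compound 2. No available evidence bears on why this step stays so small.

The compounds shown leave open whether an amine, a carboxylic acid or a longer chain on this carbon would give a step beyond the scatter. They also leave open whether any change at this position can separate a compound from compound 2 in this assay at all.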